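Moving fluorines on the aryl piperazine of an aminothiophene

The source may report more compounds than this note shows. Statements on the series, on what has been measured and on what is new or still open speak of the compounds shown alone.

Measured compounds:
compound 1 `Nc1scc(CN2CCN(c3cc(Cl)cc(Cl)c3)CC2)c1C(=O)c1ccc(Cl)cc1`, 1%
compound 2 `Nc1scc(CN2CCN(c3cccc(F)c3)CC2)c1C(=O)c1ccc(Cl)cc1`, 1%
compound 3 `Nc1scc(CN2CCN(c3ccc(F)c(F)c3)CC2)c1C(=O)c1ccc(Cl)cc1`, 0%

In an assay on CHO cells for displacement of a labelled ligand from adenosine receptor A1 (Homo sapiens), read by scintillation counting, with a stated time of 120 min, tested at 10 uM (a lower number here means less inhibition, a higher number more inhibition at the concentration tested (going by the name of the read-out)), compound 3 gives the lowest of the three numbers, yet it lies within the scatter of compound 1 and compound 2. Compound 4 `Nc1scc(CN2CCN(c3cc(F)ccc3F)CC2)c1C(=O)c1ccc(Cl)cc1` differs from compound 3 only in the aryl group on the ring nitrogen: 2,5-difluorophenyl in place of 3,4-difluorophenyl on an amine nitrogen in a ring. Two measured steps changed that same aryl group: a number 1 percentage points lower from compound 1 to compound 3 (within the scatter) and a number 1 percentage points lower from compound 2 to compound 3 (within the scatter), both within the scatter. Swapping one fluorinated phenyl for another is therefore expected to give no step beyond the scatter in this assay: a number 1 percentage points higher from compound 3 to compound 4 (within the scatter). Compound 4 is estimated at 1%, with a range from -6% to 8%.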

Compound 4, a percentage reported as inhibition, at one concentration (the size of the read-out at that concentration, not a potency): 1%
Beside the measured number, compound 4's estimate shows no gap at the digits printed; the measured number falls inside the stated range.
By their numbers in this assay, from the lowest: compounds 3, 1, 2 and 4 (each within the scatter of the next).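

In this assay the position of the fluorines on this aryl group makes no visible difference: the 2,5-difluorophenyl group gives a number 1 percentage points higher from compound 3 to compound 4 (within the scatter) when it replaces 3,4-difluorophenyl. The other comparisons agree, with fluoro in place of hydrogen giving no change at the digits printed from compound 2 to compound 4 (within the scatter) and the swap from 3,5-dichlorophenyl giving no change at the digits printed from compound 1 to compound 4 (within the scatter), so all four compounds stay within the scatter of one another. No supporting measurement explains this flat result.

The compounds shown leave open whether a different group on this ring nitrogen, such as a benzyl group or a phenyl carrying an amine or a carboxylic acid, would give a step beyond the scatter. On these data alone, whether changes elsewhere on the shared core would do so also remains open.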